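The source may hold more compounds than are shown below. What is called first, only, known or untested is meant among the compounds shown, and "the series" means these compounds.

Compound 1 `Cc1ccc(S(=O)(=O)n2cc(/C=N\c3ccc(N4CCOCC4=O)cc3)c3ccccc32)cc1`: in an ADME assay on BV-2 cells (Mus musculus) for cytotoxicity, read by MTT assay, with a stated time of 48 h, tested at 20 uM (a higher number here means a weaker effect of the compound at the concentration tested, a lower number a stronger effect), compound 1 gives 56.7%.
Compound 2 `O=C1COCCN1c1ccc(/N=C\c2cn(Cc3ccccc3)c3ccccc23)cc1`: in this assay compound 2 gives 87.8%.

For the measured compounds named here, compound 2 stands highest of the two numbers so far; its nearest neighbour is compound 1, reached by the only measured step, a number 31.1 percentage points higher from compound 1 to compound 2 (beyond the scatter). Compound 3 `O=C1COCCN1c1ccc(/N=C\c2cn(Cc3ccc(F)cc3)c3ccccc23)cc1` differs from compound 2 by fluoro in place of hydrogen on an aromatic carbon. Going by the values given here, no measured step bears on this change: the one step recorded, a number 31.1 percentage points higher from compound 1 to compound 2 (beyond the scatter), exchanges a whole group on the aromatic nitrogen and says nothing about fluoro in place of hydrogen on an aromatic carbon. A step within the scatter is therefore expected, a number 3.8 percentage points lower from compound 2 to compound 3 (within the scatter), with no clear direction. Compound 3 is estimated at 84%, between 68% and 98%.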

Compound 3, a percentage reported as activity, at one concentration (the size of the read-out at that concentration, not a potency): 84.2%
Beside the measured number, compound 3's estimate is 0.2 percentage points below it; the measured number falls inside the stated range.
By their numbers in this assay, from the lowest: compound 1; then compounds 3 and 2 (each within the scatter of the next).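

In this assay, the 4-fluorobenzyl group on the aromatic nitrogen cannot be told apart from benzyl (a number 3.6 percentage points lower from compound 2 to compound 3 (within the scatter)). The large difference from the (4-methylphenyl)sulfonyl compound persists with fluoro on the ring (a number 27.5 percentage points higher from compound 1 to compound 3 (beyond the scatter)), so it is not confined to the unsubstituted benzyl group. No evidence at hand bears on the reason for either step.

On these data alone, whether an amine or a carboxylic acid on the same ring carbon would also leave the number within the scatter remains open. So does the effect of a longer chain in place of benzyl.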